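Phenyl in Place of Pentan-3-yl on a Shared Core

The compounds below may be only part of what the source reports. "The series", "measured", "known", "first", "only" and "open" are said of these compounds alone.

Compound 1 `COc1ccc(Oc2ccc3c(NCCCNCc4cccc(OC)c4O)ccnc3c2)cc1` gives 5500 nM
Compound 2 `COc1cccc(CNCCCNc2ccnc3cc(CCC(C)C)ccc23)c1O` gives 5390 nM
Compound 3 `CCC(CC)c1ccc2c(NCCCNCc3cccc(OC)c3O)ccnc2c1` gives 410 nM

All three were measured in an ADME assay on HepG2 cells (Homo sapiens) for cytotoxicity, read by luminescence, CellTiter-Glo and ATP content, with a stated time of 72 h; a lower number here means that less compound is needed, a higher number that more compound is needed for the effect. Compound 3 has the lowest number of the three, and its steps to compound 2 and to compound 1 are both beyond the scatter. Compound 4 `COc1cccc(CNCCCNc2ccnc3cc(-c4ccccc4)ccc23)c1O` differs from compound 3 by phenyl in place of pentan-3-yl on an aromatic carbon. Among the measured compounds shown here, two measured steps bear on this change: a 13-fold lower number from compound 2 to compound 3 (1.12 log units; beyond the scatter) and a 13-fold lower number from compound 1 to compound 3 (1.13 log units; beyond the scatter), both large and both ending at pentan-3-yl. Neither step involves phenyl itself, so the direction rests on pentan-3-yl being the group paired with the low number. Exchanging it is therefore expected to raise the number for compound 4, back toward compounds 1 and 2. Compound 4 is estimated at 2500 nM, between 800 nM and 8000 nM. For compound 4 the expected change is a 6.1-fold higher number from compound 3 to compound 4 (0.79 log units; beyond the scatter).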

Compound 4, half-maximal effective concentration: 3210 nM
The estimate for compound 4 lay 1.3-fold (0.11 log units) below the measured number; measured number inside the range.
By their numbers in this assay, from the lowest: compound 3; then compounds 4, 2 and 1 (each within the scatter of the next).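

In this assay the step of a 7.8-fold higher number from compound 3 to compound 4 (0.89 log units; beyond the scatter) shows that an aromatic ring on this carbon does not keep the low number seen with pentan-3-yl. Phenyl instead falls level with the other two groups, with a 1.7-fold lower number from compound 2 to compound 4 (0.23 log units; within the scatter) and a 1.7-fold lower number from compound 1 to compound 4 (0.23 log units; within the scatter) both within the scatter. Of the four groups at this position, pentan-3-yl alone gives the low number, and no compound shown goes against that. Going by these compounds, whether cyclopentyl or an amine on this aromatic carbon would keep that low number stays open. No measurement shown here accounts for what sets pentan-3-yl apart.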